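Enlarging the Amide Substituent from Compound 2 to Compound 3

The source may report more compounds than this note shows. Statements on the series, on what has been measured and on what is new or still open speak of the compounds shown alone.

Measured so far:
Compound 1, `CCCNC(=O)CC1CCc2cc(OC)c(OC)cc21`: 29%
Compound 2, `COc1cc2c(cc1OC)C(CC(=O)NC(C)C)CC2`: 30.4%

In a functional assay on the whole organism (strain Wistar) for inhibition, with Rattus norvegicus as the target, read by paw edema, with stated times of 60 min and 3 h, at a dose of 100 mg/kg by the oral route (a lower number here means less inhibition, a higher number more inhibition at the dose given (going by the name of the read-out)), compound 1 gives 29%, and compound 2 gives 30.4%. These two differ only in that compound 2 carries isopropyl in place of propyl on an amide-type nitrogen, and the accompanying step, a number 1.4 percentage points higher from compound 1 to compound 2 (within the scatter), is within the scatter. Compound 2 therefore stands alongside compound 1, with no separation between them that the measurement can resolve.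

Compound 3, `COc1cc2c(cc1OC)C(CC(=O)NC1CCCCC1)CC2`, is not yet measured. It differs from compound 2 by cyclohexyl in place of isopropyl on an amide-type nitrogen. Within the data shown here, the only measured step that touches the same position is the one from compound 1 to compound 2, which exchanged one alkyl group for another on that nitrogen and stayed within the scatter. On that single precedent, the change to cyclohexyl is expected to bring a step of a number 0.6 percentage points higher from compound 2 to compound 3 (within the scatter) in this assay, that is, none beyond the scatter. Compound 3 is accordingly estimated at 31%, within a range from 18% to 44%.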

Compound 3, a percentage reported as inhibition, in the whole organism at one dose (the size of the read-out at that dose, not a potency): 49.3%
For compound 3 the middle estimate is 18.3 percentage points below the measured one; the measured number lies above the stated range.
By their numbers in this assay, from the lowest: compounds 1 and 2 (each within the scatter of the next); then compound 3.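

In this assay the substituent on the amide-type nitrogen proves able to move the read-out: cyclohexyl in place of isopropyl gives a number 18.9 percentage points higher from compound 2 to compound 3 (beyond the scatter), a separation that the exchange of propyl for isopropyl had not produced. Cyclohexyl in place of propyl likewise gives a number 20.3 percentage points higher from compound 1 to compound 3 (beyond the scatter), so compound 3 stands clear of both compound 1 and compound 2 and has the highest number of the three at this single dose. No measurement shown here bears on what lies behind this rise.

The change replaces 3 heavy atoms and no ring with 6 heavy atoms and a six-membered ring, so these compounds cannot tell whether the gain follows the number of carbons or the ring itself; a straight hexyl chain or a cyclopentyl group would bear on that question. Going by these compounds, it also remains open whether other groups on this nitrogen, such as phenyl or a chain ending in an amine or a carboxylic acid, would hold, raise or lose the inhibition seen with cyclohexyl.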